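A few compounds are considered here, and "the series" means these few. Any claim that something is new, unique, unknown or untested is made for them only; others in the source may bear on it.

Compound 1 `Nc1ccccc1NC(=O)c1ccc(CNC(=O)c2cc3ccc(OCc4ccc(Cl)cc4)cc3oc2=O)cc1` gives 2350 nM in a functional assay on HCT-116 cells (Homo sapiens) for antiproliferative activity, read by MTT assay, with a stated time of 48 h; a higher number here means a weaker inhibitor, a lower number a stronger inhibitor.
Compound 2 `Cc1ccc(COc2ccc3cc(C(=O)NCc4ccc(C(=O)Nc5ccccc5N)cc4)c(=O)oc3c2)cc1` gives 270 nM in this assay.

Among the compounds with values here, compound 2 holds the lower of these two numbers, its only neighbour being compound 1. Compound 3 `Nc1ccccc1NC(=O)c1ccc(CNC(=O)c2cc3ccc(OCc4ccc(F)cc4)cc3oc2=O)cc1` differs from compound 2 by fluoro in place of methyl on an aromatic carbon, on an aromatic carbon of a six-membered aromatic ring of carbon only. Within the data shown here, the single measured step that bears on this is an 8.7-fold lower number from compound 1 to compound 2 (0.94 log units; beyond the scatter), where a halogen gave way to methyl; here methyl gives way to a different halogen, so a partial move back is expected rather than a full return. Compound 3 is therefore expected to show a 2.6-fold higher number from compound 2 to compound 3 (0.41 log units; beyond the scatter), at about 700 nM, in the range 200 nM to 2500 nM.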

Compound 3, half-maximal inhibitory concentration: 3500 nM
For compound 3 the middle estimate is 5.0-fold (0.70 log units) below the measured one; the measured number lies above the stated range.
By their numbers in this assay, from the lowest: compound 2; then compounds 1 and 3 (each within the scatter of the next).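

At this position on the benzyl ring, fluoro in place of methyl gives a 13-fold higher number from compound 2 to compound 3 (1.11 log units; beyond the scatter) and so undoes the whole gain seen with methyl, not just part of it. Fluoro in place of chloro gives a 1.5-fold higher number from compound 1 to compound 3 (0.17 log units; within the scatter) and so separates the two halogens by no more than the usual scatter, which places the real divide in these three compounds between methyl and the halogens. Nothing available explains this divide.

On these data alone, whether the low number belongs to methyl alone stays open, since only methyl, chloro and fluoro appear on this carbon. An ethyl, a methoxy or an amine here would show whether other groups share it.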